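The compounds below may be only part of what the source reports. "The series", "measured", "known", "first", "only" and "open" are said of these compounds alone.

Measured compounds:
- compound 1 `CC(C)n1cnc2c(Nc3ccccc3)nc(NCOCc3ccc(C(=O)Nc4ccccc4N)cc3)nc21`: 15%
- compound 2 `CC(C)n1cnc2c(Nc3ccccc3)nc(NCOCc3ccc(/C=C/C(=O)Nc4ccccc4N)cc3)nc21`: 41%
- compound 3 `Nc1ccccc1NC(=O)/C=C/c1ccc(Cn2cnc3c(Nc4cccc(Cl)c4)nc(Cl)nc32)cc1`: 7.11%

In a functional assay on NCI-H460 cells (Homo sapiens) for antiproliferative activity, read by CCK-8 assay, with a stated time of 72 h, tested at 2 uM (on this read-out higher numbers stand for a stronger effect at the one concentration tested and lower numbers for a weaker effect), compound 2 gives the highest of the three numbers; compound 1 lies a number 26 percentage points higher from compound 1 to compound 2 (beyond the scatter) below it, and compound 3 lies further below. The unmeasured compound 4 `CC(C)n1cnc2c(Nc3cccc(Cl)c3)nc(NCOCc3ccc(/C=C/C(=O)Nc4ccccc4N)cc3)nc21` differs from compound 2 by one change: chloro in place of hydrogen on an aromatic carbon. Among the measured compounds shown here, no measured step makes this same change on the shared core of compound 2; compound 3 carries the (3-chlorophenyl)amino group but also a different core, so its value shows only that such a compound can score low. For the measured compounds named here, with no step bearing on the change, compound 4 is expected to move a number 3 percentage points lower from compound 2 to compound 4 (within the scatter) from compound 2, that is, nothing beyond the scatter. Compound 4 is therefore estimated at 38%, within 15% to 60%.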

Compound 4, a percentage reported as inhibition, at one concentration (the size of the read-out at that concentration, not a potency): 53%
Compound 4: middle estimate off by 15 percentage points, on the low side; low and high end bracket the measured number.
By their numbers in this assay, from the lowest: compounds 3 and 1 (each within the scatter of the next); then compound 2; then compound 4.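

In this assay, chloro in place of hydrogen on the anilino ring gives a number 12 percentage points higher from compound 2 to compound 4 (beyond the scatter) and so shows that this change, meta to a large group, raises the read-out on the shared core. The earlier compounds shown here could not show this, since compound 3 carries the (3-chlorophenyl)amino group on a different core. Nothing given here accounts for the rise.
As far as these compounds go, whether bromo, methoxy or an amine in the same place would move the number as chloro does stays open. So does whether the step depends on the rest of compound 4.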